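Swapping Methyl for Chloro on the Benzyl Arm

The source may hold more compounds than are shown below. What is called first, only, known or untested is meant among the compounds shown, and "the series" means these compounds.

Compound 1, `CCCn1c(=O)c2nc(-c3cnn(Cc4cccc(C)c4)c3)[nH]c2n(CCC)c1=O`, is the starting point. In an in vitro assay on HEK293 cells for displacement of a labelled ligand from adenosine receptor A2b (Homo sapiens) (a higher number here means a weaker inhibitor, a lower number a stronger inhibitor), compound 1 gives 36 nM, the lowest of the two numbers reported here. The nearest number belongs to compound 3, `CCCn1c(=O)c2nc(-c3cc(C)nn3CC)[nH]c2n(CCC)c1=O`, which gives 2100 nM in this assay; the gap between the two lies well beyond the usual scatter, so compound 1 is clearly the stronger inhibitor of the pair. Compound 2, `CCCn1c(=O)c2c(nc(-n3cc(I)cn3)n2Cc2ccccc2)n(CCC)c1=O`, gives only a limit in this assay, > 5800 nM, and so yields no number to compare.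

Compound 4, `CCCn1c(=O)c2nc(-c3cnn(Cc4cccc(Cl)c4)c3)[nH]c2n(CCC)c1=O`, has not yet been measured. It differs from compound 1 in one place: chloro in place of methyl on an aromatic carbon. For the measured compounds named here, no measured pair in this set shows the same exchange, so the expectation rests on the single-atom nature of the swap. Such a change is expected to move the number little, in either direction or not at all beyond the scatter, so the step of a 1.1-fold higher number from compound 1 to compound 4 (0.05 log units; within the scatter) is estimated as small. Compound 4 is therefore expected to give about 40 nM in this assay, within a range from 15 nM to 110 nM.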

Compound 4, inhibition constant: 18 nM
Estimate against measurement, compound 4: 2.2-fold (0.35 log units) above; the measured number falls inside the stated range.
By their numbers in this assay, from the lowest: compounds 4 and 1 (each within the scatter of the next); then compound 3. At a limit, above all of these: compound 2.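

For the compounds shown here, this is the first pair in the set that differs in one place, so it gives the first direct reading of a single change on this arm. In this assay, going from 3-methylbenzyl to 3-chlorobenzyl gives a 2.0-fold lower number from compound 1 to compound 4 (0.30 log units; within the scatter) and keeps the number low, so methyl and chloro cannot be told apart at this place on the six-membered aromatic ring. The result therefore shows that this one position accepts either group without a change that can be read beyond ordinary repeat variation, although nothing measured here explains why the two groups read alike.

Still open, on these data alone, is whether this place would accept groups of a different kind, such as a methoxy, an amine or a carboxylic acid, or a longer chain such as propyl, and whether any of these would move the number clearly in either direction. Also open is whether the same exchange of methyl for chloro would read alike elsewhere on the aromatic ring, since the compounds shown cover only this one place.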